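Bromo for nitro on the compound 1 core

A few compounds are considered here, and "the series" means these few. Any claim that something is new, unique, unknown or untested is made for them only; others in the source may bear on it.

Measured in a functional assay on PANC-1 cells (Homo sapiens) for antiproliferative activity, read by fluorescence and resazurin assay, with a stated time of 48 h; on this read-out higher numbers stand for weaker inhibition and lower numbers for stronger inhibition:
- compound 1 `CCOc1ccc2nc(Cl)c(/C=N/NC(=O)c3cc4cc([N+](=O)[O-])ccc4oc3=O)cc2c1` gives 10500 nM
- compound 2 `O=C(N/N=C/c1cccnc1)c1cc2ccccc2oc1=O` gives 15300 nM
- compound 3 `O=C(N/N=C/c1ccncc1)c1cc2cc(Br)ccc2oc1=O` gives 25700 nM

Compound 1 and compound 2 lie within the scatter of each other, while compound 3 reads higher than compound 1, beyond the scatter. The next compound, compound 4 `CCOc1ccc2nc(Cl)c(/C=N/NC(=O)c3cc4cc(Br)ccc4oc3=O)cc2c1`, keeps the core of compound 1 and carries bromo in place of nitro on an aromatic carbon. The exchange sits on a six-membered aromatic ring of carbon only, part of a fused or bridged system of two rings.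

Going by the values given here, no measured pair isolates this exchange. Compound 3 also carries a bromo and gives 25700 nM, but it differs from compound 4 elsewhere as well, so it offers only weak guidance. The expectation in this assay is therefore a small upward shift, not beyond the scatter. The estimated change is a 1.2-fold higher number from compound 1 to compound 4 (0.09 log units; within the scatter). Compound 4 is expected at 13000 nM, with an estimated range of 6000 nM to 28000 nM.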

Compound 4, half-maximal inhibitory concentration: 17000 nM
Estimate against measurement, compound 4: 1.3-fold (0.12 log units) below; the range from low to high includes it.
By their numbers in this assay, from the lowest: compounds 1, 2, 4 and 3 (each within the scatter of the next, the first and the last beyond it).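

In this assay, bromo in place of nitro on this aromatic carbon gives a 1.6-fold higher number from compound 1 to compound 4 (0.21 log units; within the scatter). This is the only pair shown that isolates a single exchange, and it indicates that on the core of compound 1 the nitro group, with its hydrogen-bond acceptors, is not required to keep the read-out in the same range. Nothing measured here speaks to the reason for this result.

The compounds shown leave open how an amine, a carboxylic acid or a methoxy group would read at this position, so the tolerance rests on two groups only. Also open, going by these compounds, is whether bromo and nitro would read alike on a core other than that of compound 1.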